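Replacing 4-hydroxy-1H-benzimidazol-2-yl in Compound 2

A few compounds are considered here, and "the series" means these few. Any claim that something is new, unique, unknown or untested is made for them only; others in the source may bear on it.

In a functional assay on HOP-62 cells (Homo sapiens) for inhibition, read by sulforhodamine B assay (on this read-out higher numbers stand for weaker inhibition of growth and lower numbers for stronger inhibition of growth), compound 2 (`Oc1cccc2[nH]c(-c3ccc(-c4ccc(-c5ccc(OC(F)(F)F)cc5)cc4)cc3)nc12`) gives 2270 nM. Compound 3 (`Oc1ccc(-c2ccc(-c3ccc(-c4nc5c(O)cccc5[nH]4)cc3)cc2)cc1`) gives 2410 nM and compound 1 (`Cc1ccc2[nH]c(-c3ccc(-c4ccc(-c5cccc(Cl)c5)cc4)cc3)nc2c1`) gives 2740 nM, so all three numbers lie within the scatter of one another and compound 2 does not stand apart from either.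

The next compound is compound 4 (`Cc1ccc2[nH]c(-c3ccc(-c4ccc(-c5ccc(OC(F)(F)F)cc5)cc4)cc3)nc2c1`). The structural change is 5-methyl-1H-benzimidazol-2-yl in place of 4-hydroxy-1H-benzimidazol-2-yl on an aromatic carbon.

Within the data shown here, no measured step makes this exchange. The only one available, a 1.1-fold higher number from compound 2 to compound 3 (0.03 log units; within the scatter), puts hydrogen in place of trifluoromethyl on an oxygen elsewhere in the molecule, and it stays within the scatter. Compound 1 offers the closest indirect evidence, since it already carries the entering 5-methyl-1H-benzimidazol-2-yl. Compound 1, at 2740 nM, lies within the scatter of compound 2 at 2270 nM. On this limited evidence, no change beyond the scatter is expected in this assay, and no direction can be favoured with confidence. The expected result is a 1.1-fold higher number from compound 2 to compound 4 (0.04 log units; within the scatter). Compound 4 is estimated at 2500 nM, with an expected range from 1300 nM to 4800 nM.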

Compound 4, concentration for 50% growth inhibition: 24200 nM
The estimate for compound 4 lay 9.7-fold (0.99 log units) below the measured number; the whole stated range lies below it.
By their numbers in this assay, from the lowest: compounds 2, 3 and 1 (each within the scatter of the next); then compound 4.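

In this assay, the exchange of 4-hydroxy-1H-benzimidazol-2-yl for 5-methyl-1H-benzimidazol-2-yl is not neutral when 4-(trifluoromethoxy)phenyl is present, giving an 11-fold higher number from compound 2 to compound 4 (1.03 log units; beyond the scatter). The entering group alone does not account for this, since compound 1 carries the same 5-methyl-1H-benzimidazol-2-yl with 3-chlorophenyl, and the exchange of that aryl group gives an 8.8-fold higher number from compound 1 to compound 4 (0.95 log units; beyond the scatter), whereas the change on the oxygen of the aryl group in the 4-hydroxy-1H-benzimidazol-2-yl series stays small, at a 1.1-fold higher number from compound 2 to compound 3 (0.03 log units; within the scatter); the two ends of these molecules therefore do not act independently across compounds 1 to 4. No measurement is available that would explain the loss of growth inhibition seen with compound 4.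

The compounds shown leave open whether the step from compound 2 follows from losing the hydroxy group, gaining the methyl group, or both, as the two changes occur together. Going by these compounds, an unsubstituted 1H-benzimidazol-2-yl, or a methoxy group or an amine in place of the hydroxy group, would help separate these possibilities, and it also remains open how 4-hydroxyphenyl behaves alongside 5-methyl-1H-benzimidazol-2-yl.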